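The compounds below may be only part of what the source reports. "The series", "measured", "known", "first", "only" and "open" are said of these compounds alone.

Working notes on the cytotoxicity series.

Compound 2 `COc1ccc(/C=C/C(=O)NCCCC(C)Nc2cc(OC)cc3cccnc23)cc1` stands at the assay limit in an ADME assay on L6 cells (Rattus norvegicus) for cytotoxicity, read by resazurin assay, with a stated time of 70 h; on this read-out lower numbers stand for stronger inhibition and higher numbers for weaker inhibition: its value of > 100 ug/mL is a limit, not a number, and the limit of > 100 ug/mL in this assay, at which 1 of the 2 values shown sits, marks where it sits. Compound 1 `COc1cc(NC(C)CCCNC(=O)/C=C/c2ccccc2)c2ncccc2c1` gives 7.2 ug/mL in this assay. Going by the values given here, the one measured step, an at least 13-fold higher number from compound 1 to compound 2 (1.14 log units; beyond the scatter), concerns methoxy in place of hydrogen on an aromatic carbon and is large.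

Compound 3 `COc1cc(NC(C)CCCNC(=O)Nc2cccc(O)c2)c2ncccc2c1` differs from compound 2 by (3-hydroxyphenyl)amino in place of 2-(4-methoxyphenyl)ethenyl on a carbonyl carbon. Among the compounds with values here, no measured step concerns this change, so the measured step gives only indirect guidance: the group that leaves carries the methoxy whose arrival coincided with the large step, and the group that enters does not. Some return toward the number of compound 1 is therefore expected, though a limit again is possible. For compound 3 the expected step is an at least 2.5-fold lower number from compound 2 to compound 3 (0.39 log units; beyond the scatter), with an estimate of 40 ug/mL spanning 8 ug/mL to 100 ug/mL.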

Compound 3, half-maximal inhibitory concentration: 38 ug/mL
Compound 3: middle estimate off by 1.1-fold (0.02 log units), on the high side, and the stated range covers the measured number.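

In this assay, the carbonyl carbon proves to be a place that moves the number: (3-hydroxyphenyl)amino in place of 2-(4-methoxyphenyl)ethenyl gives an at least 2.6-fold lower number from compound 2 to compound 3 (0.42 log units; beyond the scatter) and brings the series back from the limit to a readable value. The reading of compound 2 is a limit and not a number, so this step has a bound and no exact size: the limit of > 100 ug/mL in this assay, at which 1 of the 3 values shown sits. The same group in place of 2-phenylethenyl gives a 5.3-fold higher number from compound 1 to compound 3 (0.72 log units; beyond the scatter), so the entering group does not return the number to that of compound 1.

On these data alone, it remains open whether the hydroxy group or the amino link of the entering group carries this difference. A plain phenylamino group, or a methoxy group in place of the hydroxy group, would separate the two.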